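Working notes: lengthening the hydroxycarbamoyl chain of compound 2

The source may report more compounds than this note shows. Statements on the series, on what has been measured and on what is new or still open speak of the compounds shown alone.

Measured in a functional assay on THP-1 cells (Homo sapiens) for inhibition; on this read-out higher numbers stand for weaker inhibition of growth and lower numbers for stronger inhibition of growth:
- compound 1 `Cc1cccc(Cc2cn(CCCCCCC(=O)NO)c3ccc(-c4c(C)noc4C)cc23)c1` gives 15500 nM
- compound 2 `Cc1ccc(Cc2cn(CCCCCC(=O)NO)c3ccc(-c4c(C)noc4C)cc23)cc1` gives 15500 nM

Compound 2 (15500 nM) stands level with compound 1 (15500 nM), with no difference beyond the scatter. Both values are modest for this assay only in the sense that they are the sole reference points available.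

Compound 3 `Cc1ccc(Cc2cn(CCCCCCC(=O)NO)c3ccc(-c4c(C)noc4C)cc23)cc1` differs from compound 2 by (hydroxycarbamoyl)methyl in place of hydroxycarbamoyl on a saturated chain carbon, five bonds along the chain from an aromatic nitrogen. Among the measured compounds shown here, no measured pair shows this change on its own, so its effect is not known from the data. With compound 1 (15500 nM) and compound 2 (15500 nM) level, no shift in either direction is expected beyond the scatter. The expected change is small, an estimated step of a 1.1-fold lower number from compound 2 to compound 3 (0.04 log units; within the scatter) that stays within that scatter. For compound 3 the estimated value is 14000 nM (expected range 6000 nM to 30000 nM).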

Compound 3, concentration for 50% growth inhibition: 15500 nM
Beside the measured number, compound 3's estimate is 1.1-fold (0.04 log units) below it, and the stated range covers the measured number.
By their numbers in this assay, from the lowest: compounds 1, 2 and 3 (each within the scatter of the next).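

In this assay the chain change, (hydroxycarbamoyl)methyl in place of hydroxycarbamoyl on a saturated chain carbon, five bonds along the chain from an aromatic nitrogen, can now be read on its own and gives no change at the digits printed from compound 2 to compound 3 (within the scatter) with 4-methylphenyl held fixed. The aryl change, 4-methylphenyl in place of 3-methylphenyl on a saturated chain carbon bound to an aromatic carbon, can also be read on its own and gives no change at the digits printed from compound 1 to compound 3 (within the scatter) with the chain held fixed, so the level values of compound 1 and compound 2, which differ in two places, do not conceal two opposing shifts. No supporting data bear on why the read-out stays flat across these changes.

On these data alone, whether a longer chain such as 4-(hydroxycarbamoyl)butyl would also leave the number unmoved remains open. So does the effect of a carboxylic acid in place of the hydroxycarbamoyl end, or of a chlorine in place of the aryl methyl.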